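The compounds below may be only part of what the source reports. "The series", "measured", "known", "first", "only" and "open" are said of these compounds alone.

Measured compounds:
Compound 1 `Cc1[nH]ncc1CN1C[C@H](CCCB(O)O)[C@](N)(C(=O)O)C1` gives 400 nM in an assay for inhibition of arginase-1 (Homo sapiens), read by colorimetric assay, with a stated time of 60 min, in the presence of a further agent that is not named here; on this read-out higher numbers stand for weaker inhibition and lower numbers for stronger inhibition.
Compound 2 `Cc1nn(C)c(C)c1CN1C[C@H](CCCB(O)O)[C@](N)(C(=O)O)C1` gives 340 nM in this assay.

The two measured compounds share a core and differ only in the group on the saturated chain carbon bound to the amine nitrogen in the ring. In this assay the step of a 1.2-fold lower number from compound 1 to compound 2 (0.07 log units; within the scatter) lies within the scatter, so compound 2 and compound 1 cannot be told apart on these numbers. Compound 3 `C[C@@H](N)CN1C[C@H](CCCB(O)O)[C@](N)(C(=O)O)C1` has not yet been measured; it differs from compound 2 by 1-aminoethyl in place of 1,3,5-trimethyl-1H-pyrazol-4-yl on a saturated chain carbon bound to an amine nitrogen in a ring. Among the compounds with values here, the only measured step swaps one methylated aromatic ring for another and says nothing about removing the ring altogether in favour of a short chain, so no measured step bears on this change. With nothing to anchor it, compound 3 is expected to give a number near or somewhat above that of compound 2, the estimated step being a 2.4-fold higher number from compound 2 to compound 3 (0.37 log units; beyond the scatter), with wide uncertainty. The estimate for compound 3 in this assay is 800 nM, between 250 nM and 2500 nM.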

Compound 3, half-maximal inhibitory concentration: 16 nM
Compound 3: middle estimate off by 50-fold (1.70 log units), on the high side; the whole stated range lies above it.
By their numbers in this assay, from the lowest: compound 3; then compounds 2 and 1 (each within the scatter of the next).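

In this assay the swap of either ring for 1-aminoethyl gives a 21-fold lower number from compound 2 to compound 3 (1.33 log units; beyond the scatter) and a 25-fold lower number from compound 1 to compound 3 (1.40 log units; beyond the scatter) as large steps, so the group at this place matters a great deal. Compound 1 and compound 2 could not be told apart, so they gave no hint that this place could respond so strongly, or that an aromatic ring is not needed here for strong inhibition. This change removes a ring and brings in an amine and a defined stereocentre all at once, and nothing available here says which of these accounts for the gain.

Going by these compounds, whether a plain ethyl group, without the amine, would keep the low number remains open. So does whether the mirror-image 1-aminoethyl group or a longer aminoalkyl chain would do as well as the group in compound 3.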